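This account rests on a few compounds, and the source may have more. Where it says the series, first, only, none or still open, it means among the compounds named here.

Three related compounds have been measured in a functional assay on cells (Endothelial cell, Bos taurus) for antiproliferative activity; on this read-out lower numbers stand for stronger inhibition and higher numbers for weaker inhibition. Compound 2 `COc1ccc(/C(F)=C(/F)c2cc(OC)c(OC)c(OC)c2)cc1N` gives 3600 nM, which places it with compound 3 `COc1ccc(/C(F)=C(/F)c2cc(OC)c(OC)c(OC)c2)cc1O`, at 4600 nM, at the weaker end of this small set, while compound 1 `COc1cc(/C(F)=C/c2cc(O)c3ccsc3c2)cc(OC)c1OC`, at 390 nM, lies well below both. Putting hydroxy in place of amino gives a 1.3-fold higher number from compound 2 to compound 3 (0.11 log units; within the scatter), so that swap leaves no real mark on the read-out.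

Compound 4 `COc1ccc(/C(F)=C(\F)c2cc(OC)c(OC)c(OC)c2)cc1N` has the same atoms and bonds as compound 2 and differs only in configuration as drawn: the two compounds have the same atoms and bonds and differ only in configuration as drawn: 1 of 1 stereo elements differ; a double bond is drawn Z in compound 2 and E in compound 4, with a double bond drawn Z in compound 2 and E in compound 4. For the measured compounds named here, the single measured step swaps a group and leaves the configuration alone, so it offers only weak guidance here. Going by the values given here, compound 1 differs from compound 2 in more than configuration, and no measured pair isolates this kind of change. The direction is therefore a cautious judgement, with weaker inhibition the more likely outcome. The estimated change is a 3.3-fold higher number from compound 2 to compound 4 (0.52 log units; beyond the scatter). Compound 4 is expected at 12000 nM, with an estimated range from 3000 nM to 50000 nM.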

Compound 4, half-maximal inhibitory concentration: 204000 nM
For compound 4 the middle estimate is 17-fold (1.23 log units) below the measured one; measured number outside the range, above it.
By their numbers in this assay, from the lowest: compound 1; then compounds 2 and 3 (each within the scatter of the next); then compound 4.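

The earlier compounds shown here showed only that putting hydroxy in place of amino leaves this assay essentially unmoved, so they said nothing about the shape of the molecule. Reversing the arrangement around the double bond, with nothing added or removed, gives a 57-fold higher number from compound 2 to compound 4 (1.75 log units; beyond the scatter), a large step that far exceeds the effect of that group swap. The geometry of the fluorinated double bond therefore matters greatly in this pair, and the step can be traced to a single difference: the fact that compounds 2 and 4 differ only in the configuration as drawn

The compounds shown leave open whether the same reversal would carry the same weight with hydroxy in place of amino, as in compound 3. Also open, from the compounds shown here alone, is how a carboxylic acid or a nitrile in place of amino would fare in either configuration.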